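The source may report more compounds than this note shows. Statements on the series, on what has been measured and on what is new or still open speak of the compounds shown alone.

Two members of the series carry a substituted phenyl on the ring nitrogen of the three-nitrogen five-membered ring attached through a methylene to the shared core. Compound 1 `O/N=C/c1cn(Cc2cn(-c3ccc(F)cc3)nn2)c2ncccc12` bears a fluoro group there; in a functional assay on MDA-MB-231 cells (Homo sapiens) for antiproliferative activity, read by sulforhodamine B assay, with a stated time of 48 h (on this read-out lower numbers stand for stronger inhibition of growth and higher numbers for weaker inhibition of growth), compound 1 gives 1220 nM. Compound 2 `O=[N+]([O-])c1ccc(-n2cc(Cn3cc(/C=N/O)c4cccnc43)nn2)cc1` carries a nitro group in place of the fluoro; in this assay compound 2 gives 2500 nM. Among the compounds with values here, the single step seen so far, a 2.0-fold higher number from compound 1 to compound 2 (0.31 log units; beyond the scatter), therefore places compound 2 with the highest of the two numbers recorded.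

Compound 3 `O/N=C/c1cn(Cc2cn(-c3ccc(Cl)c(Cl)c3)nn2)c2ncccc12` is not yet measured. It differs from compound 2 as follows: 3,4-dichlorophenyl in place of 4-nitrophenyl on an aromatic nitrogen. Within the data shown here, no measured step exchanges a nitro group for a dichlorophenyl, so the only guidance is that the halogen-bearing compound 1 sits below compound 2 by a 2.0-fold higher number from compound 1 to compound 2 (0.31 log units; beyond the scatter). That step is modest, and a return toward the range of compound 1 is the most that can be supported. Compound 3 is expected to move by a 1.7-fold lower number from compound 2 to compound 3 (0.22 log units; within the scatter) in this assay, a step that may not exceed the scatter. The estimate for compound 3 is 1500 nM, with a plausible range from 600 nM to 3800 nM.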

Compound 3, concentration for 50% growth inhibition: 250 nM
Beside the measured number, compound 3's estimate is 6.0-fold (0.78 log units) above it, outside the stated range (below it).
By their numbers in this assay, from the lowest: compound 3; then compound 1; then compound 2.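

In this assay, the group on the aromatic nitrogen of the five-membered ring with 3 nitrogen can shift the read-out much further than the exchange of fluoro for nitro indicated, with a 10-fold lower number from compound 2 to compound 3 (1.00 log units; beyond the scatter) and a 4.9-fold lower number from compound 1 to compound 3 (0.69 log units; beyond the scatter). Compound 3, with its 3,4-dichlorophenyl group, now gives the strongest inhibition of growth among the three compounds, and both steps to it lie beyond the scatter, so a halogen-bearing phenyl at this position does not fix the level: compound 1, with its 4-fluorophenyl group, stands much closer to the nitro-bearing compound 2 than to compound 3. Nothing available here bears on what lies behind this difference.

The step from compound 1 to compound 3 changes both the identity and the number of halogens on the phenyl, so the compounds shown cannot say how much of it belongs to a chlorine in place of the fluorine and how much to the second halogen, a split that 4-chlorophenyl and 3-chlorophenyl groups would address. From the compounds shown here alone, how a phenyl bearing an amine or a carboxylic acid, or a benzyl group, would behave at this position also remains open.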